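Bromo in place of hydrogen on a fused ring

The source may hold more compounds than are shown below. What is called first, only, known or untested is meant among the compounds shown, and "the series" means these compounds.

Measured so far:
Compound 1, `COc1ccc2[nH]cc(C(=O)/C(C#N)=C/C=C(\Cl)c3ccc(OC)c(OC)c3)c2c1`: "not determined" (no result reported)
Compound 2, `COc1cc(/C(Cl)=C/C=C(\C#N)C(=O)c2c[nH]c3ccc(Br)cc23)cc(OC)c1OC`: 22100 nM
Compound 3, `COc1ccc(/C(Cl)=C/C=C(\C#N)C(=O)c2c[nH]c3ccccc23)cc1OC`: "not determined" (no result reported)

In an ADME assay on Vero cells (Chlorocebus sabaeus) for cytotoxicity, read by sulforhodamine B assay, with a stated time of 48 h (a lower number here means a stronger inhibitor of growth, a higher number a weaker inhibitor of growth), compound 2 gives 22100 nM. For compound 3, `COc1ccc(/C(Cl)=C/C=C(\C#N)C(=O)c2c[nH]c3ccccc23)cc1OC`, the entry in this assay is "not determined" (no result reported), and compound 1 likewise has "not determined" (no result reported), so compound 3 cannot be placed against any measured neighbour. Compound 4, `COc1ccc(/C(Cl)=C/C=C(\C#N)C(=O)c2c[nH]c3ccc(Br)cc23)cc1OC`, differs from compound 3 by bromo in place of hydrogen on an aromatic carbon. Among the compounds with values here, no step between measured compounds is available, so the size and direction of this change are unknown; the expectation is that it stays within the usual scatter. Compound 4 is expected to give about 20000 nM, with a range from 8000 nM to 50000 nM. This rests on compound 2, which carries the same bromo and gives 22100 nM.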

Compound 4, concentration for total growth inhibition: 38400 nM
The estimate for compound 4 lay 1.9-fold (0.28 log units) below the measured number; measured number inside the range.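

In this assay, within the data shown here, the only step that can be read runs a 1.7-fold higher number from compound 2 to compound 4 (0.24 log units; within the scatter), with hydrogen in place of methoxy and the bromo kept. With bromo present, this methoxy therefore makes no difference that can be told from the scatter. No supporting data bear on this result.

Going by these compounds, the step from compound 3 to compound 4 cannot be read, as compound 3 has no single number, so the effect of the bromo itself stays unknown. Also open, on these data alone, is how an amine or a carboxylic acid would behave in place of the bromo.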